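Swapping the Terminal Aryl Group: Chloro to Methyl

This account rests on a few compounds, and the source may have more. Where it says the series, first, only, none or still open, it means among the compounds named here.

Compound 2 `O=C(Nc1ccc(Oc2ccnc3[nH]ccc23)cc1)c1cc(-c2ccc(Cl)cc2)ccn1` gives 4310 nM in a functional assay on A549 cells (Homo sapiens) for cytotoxicity, read by MTT assay, with a stated time of 72 h; on this read-out lower numbers stand for stronger inhibition and higher numbers for weaker inhibition. Of the two numbers recorded so far, its own is the smaller, but compound 1 `COc1ccc(-c2ccnc(C(=O)Nc3ccc(Oc4ccnc5[nH]ccc45)cc3)c2)cc1` lies within the scatter of it: in this assay compound 1 gives 6970 nM, and the step of a 1.6-fold lower number from compound 1 to compound 2 (0.21 log units; within the scatter) is too small to rank the pair. Compound 3 `Cc1cccc(-c2ccnc(C(=O)Nc3ccc(Oc4ccnc5[nH]ccc45)cc3)c2)c1` has not yet been measured in this assay. It differs from compound 2 in one place: 3-methylphenyl in place of 4-chlorophenyl on an aromatic carbon. Among the compounds with values here, the only measured step that bears on this position is the one from compound 1 to compound 2, a swap of methoxy for chloro on the same ring, and it moved the number by no more than the scatter. Nothing measured here separates a methyl from a chloro at this position, so the expectation rests on that single small step. Compound 3 is therefore expected to sit close to compound 2, with the step of a 1.2-fold higher number from compound 2 to compound 3 (0.06 log units; within the scatter) expected to stay within the scatter. The estimate for compound 3 in this assay is 5000 nM, with a range from 2000 nM to 13000 nM.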

Compound 3, half-maximal inhibitory concentration: 7010 nM
Estimate against measurement, compound 3: 1.4-fold (0.15 log units) below, and the stated range covers the measured number.
By their numbers in this assay, from the lowest: compounds 2, 1 and 3 (each within the scatter of the next).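

In this assay, the step from the chlorinated to the methylated compound (a 1.6-fold higher number from compound 2 to compound 3 (0.21 log units; within the scatter)) lies within the scatter, even though 3-methylphenyl differs from 4-chlorophenyl in both the substituent and its place on the ring. The comparison with the methoxy compound (a 1.0-fold higher number from compound 1 to compound 3 (0.00 log units; within the scatter)) also lies within the scatter, so compound 1, compound 2 and compound 3 cannot be ranked, and this read-out does not separate 4-methoxyphenyl, 4-chlorophenyl and 3-methylphenyl at this position on the shared core. Nothing available explains why these three values stay within the scatter of one another.

The compounds shown leave open whether any group at this position can produce a step beyond the scatter, and an amine or a carboxylic acid on the terminal ring, or a longer chain in place of the methyl, would bear on that. They also leave open whether the kind of substituent and its place on the ring count separately, since compound 2 and compound 3 differ in both.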